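Notes on the step from compound 3 to compound 4

The source may hold more compounds than are shown below. What is called first, only, known or untested is meant among the compounds shown, and "the series" means these compounds.

Three compounds have numbers in a functional assay on ME-180 cells (Homo sapiens) for cytotoxicity, read by MTT assay, with a stated time of 72 h; on this read-out higher numbers stand for weaker inhibition and lower numbers for stronger inhibition. Compound 1 `COc1ccc(C(=O)c2cc(OC)c(OC)c(OC)c2)cc1NC(=O)/C=C/c1cc(OC)c(OC)c(OC)c1` gives 2100 nM. Compound 2 `COc1ccc(C(=O)c2cc(OC)c(OC)c(OC)c2)cc1NC(=O)/C=C/c1ccc(F)c(F)c1` gives 8900 nM. Compound 3 `COc1cc(C(=O)c2cc(OC)c(OC)c(OC)c2)cc(NC(=O)/C=C/c2cc(OC)c(OC)c(OC)c2)c1OC` gives 3900 nM; on the numbers shown it stands second highest of the three, nearest to compound 1, with that gap within the scatter, and furthest from compound 2, with that gap beyond the scatter.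

Compound 4 `COc1cccc(/C=C/C(=O)Nc2cc(C(=O)c3cc(OC)c(OC)c(OC)c3)cc(OC)c2OC)c1` is not yet measured. It differs from compound 3 in one place: 3-methoxyphenyl in place of 3,4,5-trimethoxyphenyl on a double-bonded chain carbon bound to a double-bonded chain carbon.

Among the measured compounds shown here, two measured steps bear on this. a 4.2-fold higher number from compound 1 to compound 2 (0.63 log units; beyond the scatter) exchanged the same trimethoxyphenyl at the same chain carbon for a ring without methoxy groups. a 1.9-fold higher number from compound 1 to compound 3 (0.27 log units; within the scatter) concerns another position and is small. Because a 4.2-fold higher number from compound 1 to compound 2 (0.63 log units; beyond the scatter) was only modest while compound 4 keeps one methoxy of the three, compound 4 is expected to show a 2.3-fold higher number from compound 3 to compound 4 (0.36 log units; beyond the scatter) in this assay. Compound 4 is accordingly estimated at 9000 nM, within a range of 3500 nM to 25000 nM.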

Compound 4, half-maximal inhibitory concentration: 8600 nM
Compound 4: the middle estimate sits 1.0-fold (0.02 log units) above what was measured; the range from low to high includes it.
By their numbers in this assay, from the lowest: compounds 1 and 3 (each within the scatter of the next); then compounds 4 and 2 (each within the scatter of the next).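

In this assay, the exchange on a double-bonded chain carbon bound to a double-bonded chain carbon gives a 2.2-fold higher number from compound 3 to compound 4 (0.34 log units; beyond the scatter) on the core of compound 3. The direction therefore matches the earlier 4.2-fold higher number from compound 1 to compound 2 (0.63 log units; beyond the scatter) and now holds on two cores. The earlier step introduced fluorine while removing every methoxy, whereas 3-methoxyphenyl introduces no new kind of group, showing that loss of methoxy groups alone accompanies a step beyond the scatter at this position, and no measurement shown gives a reason for it.

It remains open which of the two methoxy groups lost from 3,4,5-trimethoxyphenyl accounts for the step, as 3-methoxyphenyl is the only partly stripped ring shown. Also open, on these data alone, is how an unsubstituted phenyl, or a phenyl carrying an amine or a carboxylic acid, would read at this position.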